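A Halogenated Phenyl Replaces the Methylphenyl

The compounds below may be only part of what the source reports. "The series", "measured", "known", "first", "only" and "open" are said of these compounds alone.

Compound 1 `CCC(C)c1ccc(OCc2nnc(NC(=O)Nc3ccccc3OC)s2)cc1` gives 4170 nM in an assay for inhibition of receptor-type tyrosine-protein phosphatase epsilon (Homo sapiens), read by malachite green, with a stated time of 60 min; a higher number here means a weaker inhibitor, a lower number a stronger inhibitor.
Compound 2 `Cc1ccc(NC(=O)Nc2nnc(COc3ccc(C)cc3C)s2)cc1` gives 2470 nM in this assay.

Compound 2 holds the lowest of the two numbers, and its nearest neighbour is compound 1, whose number is only slightly higher; that gap lies within the usual scatter, so the two compounds cannot be told apart on these data. Compound 3 `Cc1ccc(OCc2nnc(NC(=O)Nc3ccc(F)c(Cl)c3)s2)c(C)c1` has not yet been measured. It differs from compound 2 in one place: 3-chloro-4-fluorophenyl in place of 4-methylphenyl on an amide-type nitrogen. Everything else in the shared core of compound 2 stays as it is.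

Among the compounds with values here, no measured pair shows what such an exchange does in this assay, so nothing here tells its direction or size. The most defensible expectation is a step no larger than the scatter, with a slight lean toward a lower number. Compound 3 is therefore estimated to give 2000 nM in this assay, with a range from 700 nM to 6000 nM. This estimate means a step of a 1.2-fold lower number from compound 2 to compound 3 (0.09 log units; within the scatter), expected to sit within the scatter.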

Compound 3, half-maximal inhibitory concentration: 1860 nM
The estimate for compound 3 lay 1.1-fold (0.03 log units) above the measured number; the measured number falls inside the stated range.
By their numbers in this assay, from the lowest: compounds 3, 2 and 1 (each within the scatter of the next, the first and the last beyond it).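

In this assay, the exchange of 4-methylphenyl for 3-chloro-4-fluorophenyl on the amide-type nitrogen gives a 1.3-fold lower number from compound 2 to compound 3 (0.12 log units; within the scatter) and so leaves the two compounds indistinguishable on these data. Within the data shown here, this is the first step that can be read in one place, since compound 1 and compound 2 differ in more than one place and offered no such comparison. It shows that, with the rest of the shared core held constant, this aromatic ring can swap its methyl group for two halogen atoms without a change beyond the usual scatter, although nothing available explains that outcome or links it to any property of either group.

This single step cannot show whether the chlorine or the fluorine matters more, or whether their contributions offset each other, so rings carrying only one of these halogens would be needed to separate them. Also open, on these data alone, is how far this tolerance extends, for example whether a carboxylic acid or an amine on this ring, or a longer chain in its place, would move the number beyond the scatter.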